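Branched esters of an adenine derivative: toxicity expectations

The compounds below may be only part of what the source reports. "The series", "measured", "known", "first", "only" and "open" are said of these compounds alone.

Measured compounds in a functional assay on PRK cells (Oryctolagus cuniculus) for cytotoxicity; on this read-out higher numbers stand for lower toxicity in this test and lower numbers for higher toxicity in this test:
- compound 1 `CCCCOC(=O)C(O)Cn1cnc2c(N)ncnc21` gives 200 ug/mL
- compound 2 `CCCOC(=O)C(O)Cn1cnc2c(N)ncnc21` gives 100 ug/mL
- compound 3 `CC(C)(C)OC(=O)C(O)Cn1cnc2c(N)ncnc21` gives > 400 ug/mL, which is a limit of the assay and not a number

These three share one core and differ only in the ester group. Compound 3 is known only as a limit (the limit of > 400 ug/mL in this assay, at which 1 of the 3 values shown sits), so its exact place among the three is not settled. From compound 1 the step runs an at least 2.0-fold higher number from compound 1 to compound 3 (0.30 log units; that floor lies within the scatter), and from compound 2 it runs an at least 4.0-fold higher number from compound 2 to compound 3 (0.60 log units; beyond the scatter).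

Compound 4 `CCC(C)OC(=O)C(O)Cn1cnc2c(N)ncnc21` has not yet been measured. Compared with compound 3 the change is sec-butyl in place of tert-butyl on an oxygen next to a carbonyl group. The branched group stays, but it is cut back toward the straight chain of compound 1, so the two measured steps toward compound 3 bear on it in reverse: an expected modest drop, an at least 1.3-fold lower number from compound 3 to compound 4 (0.12 log units; that floor lies within the scatter), back toward the value of compound 1. Compound 4 is therefore estimated at 300 ug/mL, with a range from 150 ug/mL to 800 ug/mL.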

Compound 4, minimum cytotoxic concentration: > 400 ug/mL
Compound 4: a limit, no number; the forecaster's own chance of this, stated with the estimate: 35%; at least 1.3-fold (0.12 log units) between middle value and limit.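

In this assay compound 4 gives > 400 ug/mL, which is a limit of the assay and not a number. On this ester oxygen, then, the full tert-butyl group is not needed to reach that limit, as one methyl in place of hydrogen on the carbon bound to the oxygen already gives an at least 4.0-fold higher number from compound 2 to compound 4 (0.60 log units; beyond the scatter), although the comparison with the straight butyl ester is less firm, at an at least 2.0-fold higher number from compound 1 to compound 4 (0.30 log units; that floor lies within the scatter). The step between compound 3 and compound 4 cannot be read, because both values are limits: the limit of > 400 ug/mL in this assay, at which 2 of the 4 values shown sit.

As far as these compounds go, how far either branched ester lies past the limit, and so whether sec-butyl and tert-butyl differ at all, stays unknown. From the compounds shown here alone, whether an isopropyl ester or a longer branched chain such as 3-pentyl would also reach the limit stays open too.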